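This account rests on a few compounds, and the source may have more. Where it says the series, first, only, none or still open, it means among the compounds named here.

Measured compounds:
compound 1 `O=C(Nc1nc2ccc(F)cc2s1)c1cn(-c2ccccc2)nc1-c1ccccc1`: in an ADME assay on HEK-293T cells (Homo sapiens) for cytotoxicity, read by MTT assay, with a stated time of 72 h (on this read-out higher numbers stand for weaker inhibition and lower numbers for stronger inhibition), compound 1 gives 17600 nM.
compound 2 `COc1ccc2nc(NC(=O)c3cn(-c4ccccc4)nc3-c3ccccc3)sc2c1`: compound 2 gives > 50000 nM, which is a limit of the assay and not a number.

Compound 2 therefore stands at the upper edge of the numbers shown, with only a range known; the limit of > 50000 nM in this assay, at which 1 of the 2 values shown sits, marks where it sits. Among the measured compounds shown here, the one measured step is an at least 2.8-fold higher number from compound 1 to compound 2 (0.45 log units; beyond the scatter), which carried compound 2 onto that limit. Compound 3 `COc1ccc(-c2nn(-c3ccccc3)cc2C(=O)Nc2nc3ccc(OC)cc3s2)cc1` differs from compound 2 by methoxy in place of hydrogen on an aromatic carbon, a change on the phenyl rather than on the shared core, so the measured step touches a different part of the molecule and is only a loose guide. For the measured compounds named here, with compound 2 already at the limit and no measured step pointing toward a lower number, no step beyond the scatter is expected in this assay, and the expected step is a step that the limit leaves unreadable from compound 2 to compound 3. Compound 3 is estimated at 60000 nM, within 25000 nM to 150000 nM, most likely reported again only as a limit.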

Compound 3, half-maximal inhibitory concentration: > 50000 nM
Compound 3: a limit, no number; the forecaster's own chance of this, stated with the estimate: 75%; the middle value is on the limit's open side.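

In this assay compound 3 gives > 50000 nM, which is a limit and not a number. Among the compounds shown here, compound 2 sits at the same limit, so no step from compound 2 to compound 3 can be read. The compounds shown leave open whether phenyl to 4-methoxyphenyl shifts the number at all.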